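The source may hold more compounds than are shown below. What is called first, only, known or untested is meant among the compounds shown, and "the series" means these compounds.

Within the data shown here, compound 2 `COc1n[nH]c2ncc(-c3cn(-c4c(F)ccc(NS(=O)(=O)c5ccc6ccccc6c5)c4F)nn3)cc12` stands with the lowest of the two numbers so far in an assay on Sf9 cells for inhibition of mitogen-activated protein kinase kinase kinase 20 (Homo sapiens), read by ADP-Glo, with a stated time of 30 min; a lower number here means a stronger inhibitor, a higher number a weaker inhibitor: compound 2 gives 4.5 nM. Compound 1 `COc1n[nH]c2ncc(-c3cn(-c4c(F)ccc(NS(=O)(=O)c5cccc(C(C)C)c5)c4F)nn3)cc12` is the nearest neighbour; in this assay compound 1 gives 6.9 nM, and a 1.5-fold lower number from compound 1 to compound 2 (0.19 log units; within the scatter) lies within the scatter. Compound 3 `COc1n[nH]c2ncc(-c3cn(-c4c(F)ccc(NS(=O)(=O)c5cccc6ccccc56)c4F)nn3)cc12` differs from compound 2 by naphthalen-1-yl in place of naphthalen-2-yl on a sulfonyl sulfur. Among the measured compounds shown here, only that single measured step bears on the sulfonyl substituent, and no measured step exchanges one naphthyl for the other. A move of a 1.6-fold higher number from compound 2 to compound 3 (0.19 log units; within the scatter) is therefore expected, within the scatter, in either direction. Compound 3 is estimated at 7 nM, with a range of 2.5 nM to 25 nM.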

Compound 3, half-maximal inhibitory concentration: 4.2 nM
Compound 3: middle estimate off by 1.7-fold (0.22 log units), on the high side, and the stated range covers the measured number.
By their numbers in this assay, from the lowest: compounds 3, 2 and 1 (each within the scatter of the next).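

In this assay, the sulfonyl sulfur takes naphthalen-1-yl as readily as naphthalen-2-yl: the data show a 1.1-fold lower number from compound 2 to compound 3 (0.03 log units; within the scatter), so the two attachments of the naphthalene cannot be told apart here. The data also show a 1.6-fold lower number from compound 1 to compound 3 (0.22 log units; within the scatter), which places naphthalen-1-yl level with 3-isopropylphenyl and leaves all three substituents on a par at this position. Nothing in hand explains this flat result. From the compounds shown here alone, all three groups are carbon-only aromatic substituents, so it remains open whether an amine, a carboxylic acid or a short alkyl chain on the sulfonyl sulfur would hold this level.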